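A few compounds are considered here, and "the series" means these few. Any claim that something is new, unique, unknown or untested is made for them only; others in the source may bear on it.

Measured so far in a functional assay on A549 cells (Homo sapiens) for inhibition, read by sulforhodamine B assay, with a stated time of 48 h; a higher number here means a weaker inhibitor, a lower number a stronger inhibitor:

Compound 1 `O=c1c(C2N=C(c3ccccc3)SS2)coc2ccc(Cl)cc12`: 71300 nM
Compound 2 `O=c1c(C2N=C(c3ccccc3)SS2)coc2cc(Cl)c(Cl)cc12`: 95000 nM

Compound 2 shows the higher of these two numbers, and its nearest neighbour is compound 1, separated only by the step of a 1.3-fold higher number from compound 1 to compound 2 (0.12 log units; within the scatter), which lies within the scatter. Compound 3 `O=c1c(C2N=C(c3ccccc3)SS2)coc2cc(Cl)ccc12` differs from compound 2 by hydrogen in place of chloro on an aromatic carbon. For the measured compounds named here, the one measured step that bears on this change is the addition of a chloro group, a 1.3-fold higher number from compound 1 to compound 2 (0.12 log units; within the scatter); as it stayed within the scatter, removing a chloro group is not expected to move the number in this assay beyond the scatter either. Compound 3 is therefore estimated at 75000 nM, within 35000 nM to 160000 nM, an expected step of a 1.3-fold lower number from compound 2 to compound 3 (0.10 log units; within the scatter).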

Compound 3, half-maximal inhibitory concentration: 57500 nM
Compound 3: middle estimate off by 1.3-fold (0.12 log units), on the high side; the measured number falls inside the stated range.
By their numbers in this assay, from the lowest: compounds 3, 1 and 2 (each within the scatter of the next).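

In this assay the loss of this chloro group gives a 1.7-fold lower number from compound 2 to compound 3 (0.22 log units; within the scatter) and so stays inside the scatter. The chloro group leaving here is not the one added in the earlier step, so both chloro positions in compound 2 have now been changed singly without a shift beyond the scatter. Nothing measured here offers a reason for this.

Still open, on these data alone, is whether an amine, a methoxy group or a carboxylic acid on this aromatic carbon would move the number beyond the scatter.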